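Replacing a Naphthyl Group with a 4-Bromophenyl Group

The compounds below may be only part of what the source reports. "The series", "measured", "known", "first", "only" and "open" are said of these compounds alone.

Measured compounds:
Compound 1 `O=S(=O)(NCCCNCc1cccc2ccccc12)c1cc(C(F)(F)F)cc(C(F)(F)F)c1` — 2600 nM
Compound 2 `O=S(=O)(NCCCCNCc1ccc(Br)cc1)c1cc(C(F)(F)F)cc(C(F)(F)F)c1` — 1600 nM
Compound 3 `O=S(=O)(NCCCNCc1ccccc1)c1cc(C(F)(F)F)cc(C(F)(F)F)c1` — 15000 nM

In a functional assay on HT-29 cells (Homo sapiens) for inhibition, read by MTT assay, with a stated time of 72 h (on this read-out higher numbers stand for weaker inhibition of growth and lower numbers for stronger inhibition of growth), compound 1 gives 2600 nM, the second highest of the three numbers. Compound 2 sits nearest, with a value within the usual scatter of compound 1, while compound 3 lies furthest from compound 1.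

The unmeasured compound 4 `O=S(=O)(NCCCNCc1ccc(Br)cc1)c1cc(C(F)(F)F)cc(C(F)(F)F)c1` differs from compound 1 in one place: 4-bromophenyl in place of naphthalen-1-yl on a saturated chain carbon bound to an amine nitrogen.

Among the measured compounds shown here, two measured steps bear on this change. The step of a 5.8-fold higher number from compound 1 to compound 3 (0.76 log units; beyond the scatter) shows that removing the second aromatic ring of naphthalen-1-yl in favour of plain phenyl weakens growth inhibition. The step of a 9.4-fold higher number from compound 2 to compound 3 (0.97 log units; beyond the scatter) shows that 4-bromobenzyl on a longer chain is clearly more potent than benzyl on the shorter one, although that step changes the chain as well as the ring. Compound 2, which carries the 4-bromobenzyl group, gives a value within the scatter of compound 1, so the bromine appears to recover roughly what the second ring contributes. Compound 4 is therefore expected to land close to compound 1, with a step of a 1.3-fold lower number from compound 1 to compound 4 (0.11 log units; within the scatter) that stays within the scatter. The estimate for compound 4 in this assay is 2000 nM, with a range from 800 nM to 5000 nM.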

Compound 4, concentration for 50% growth inhibition: 2200 nM
Beside the measured number, compound 4's estimate is 1.1-fold (0.04 log units) below it; the range from low to high includes it.
By their numbers in this assay, from the lowest: compounds 2, 4 and 1 (each within the scatter of the next); then compound 3.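

In this assay, at this place on a saturated chain carbon bound to an amine nitrogen, one ring carrying bromine stands level with the two rings of naphthalen-1-yl on the same chain (a 1.2-fold lower number from compound 1 to compound 4 (0.07 log units; within the scatter)). Compound 4 also separates the two changes that were mixed in the earlier comparison of compound 2 with compound 3: with the chain held constant, bromo in place of hydrogen on an aromatic carbon gives a step beyond the scatter (a 6.8-fold lower number from compound 3 to compound 4 (0.83 log units; beyond the scatter)). With the 4-bromobenzyl group held constant, the chain change stays within the scatter (a 1.4-fold higher number from compound 2 to compound 4 (0.14 log units; within the scatter)), so among these compounds the larger difference follows the bromine and not the chain length.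

The compounds shown leave open whether a chloro or methoxy group in place of bromo would hold the same level, and whether naphthalen-1-yl would also tolerate the longer chain. Nothing given here explains why the bromine and the second ring lead to values within the scatter of each other.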